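Compound 3 to compound 4: isobutoxy replaced by trifluoromethyl

This account rests on a few compounds, and the source may have more. Where it says the series, first, only, none or still open, it means among the compounds named here.

Of the compounds shown here, three with a shared core have been read in an ADME assay on HepG2 cells (Homo sapiens) for cytotoxicity, read by luminescence, with a stated time of 72 h; on this read-out higher numbers stand for an effect only at larger amounts of compound and lower numbers for an effect already at smaller amounts: compound 1 `CCOC(=O)c1c(-c2ccccc2)[nH]c2cc(OC)ccc2c1=O`, compound 2 `C=Cc1cccc(-c2[nH]c3cc(OC)ccc3c(=O)c2C(=O)OCC)c1` and compound 3 `CCOC(=O)c1c(-c2cccc(OCC(C)C)c2)[nH]c2cc(OC)ccc2c1=O`. Compound 1 gives > 21500 nM, which is a limit. Compound 2 gives > 21500 nM, which is also a limit. Compound 3 gives > 21500 nM, again a limit, so it has no numeric value to start from. The set as a whole shows (the limit of > 21500 nM in this assay, at which 3 of the 3 values shown sit).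

Compound 4 `CCOC(=O)c1c(-c2cccc(C(F)(F)F)c2)[nH]c2cc(OC)ccc2c1=O` carries trifluoromethyl in place of isobutoxy on an aromatic carbon, meta to a large group: trifluoromethyl in place of isobutoxy on an aromatic carbon. The measured changes bearing on this swap are a step that the two limits leave unreadable from compound 1 to compound 2, a step that the two limits leave unreadable from compound 1 to compound 3 and a step that the two limits leave unreadable from compound 2 to compound 3. None of the three has a readable size, and none gives a direction. On these steps, no readable step is expected in this assay, and a further reading at the limit is the likeliest outcome. The estimated change is a step that the limit leaves unreadable from compound 3 to compound 4, a figure that carries little weight while the starting point is only a limit. Compound 4 is expected at 30000 nM. The estimated range for this compound runs from 15000 nM to 60000 nM.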

Compound 4, half-maximal effective concentration: > 21500 nM
Compound 4: a limit, no number; the forecaster's own chance of this, stated with the estimate: 85%; the middle value lies beyond the limit too.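

Compound 4 sits at a limit, as do compound 1, compound 2 and compound 3, so no step among these four compounds can be read in this assay: the limit of > 21500 nM in this assay, at which 4 of the 4 values shown sit. The compounds shown leave open whether any group at this place on the shared core would give a numeric value in this assay, and in which direction it would lie.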